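The source may hold more compounds than are shown below. What is called first, only, known or untested is meant among the compounds shown, and "the series" means these compounds.

Compound 1 `CNC1=NS(=O)(=O)c2cc(F)ccc2N1` is the starting point of this small series. In a functional assay (aorta) with Rattus norvegicus as the target (on this read-out lower numbers stand for an effect already at smaller amounts and higher numbers for an effect only at larger amounts of compound), compound 1 reaches only the assay limit of > 300 uM. Compound 3 `CNC1=NS(=O)(=O)c2cc(Br)ccc2N1` differs from it by bromo in place of fluoro on an aromatic carbon, and in this assay compound 3 gives 31 uM. The resulting step is an at least 9.6-fold lower number from compound 1 to compound 3 (0.98 log units; beyond the scatter); its true size is uncertain because of the limit of > 300 uM in this assay, at which 2 of the 3 values shown sit. Compound 2 `O=S1(=O)NC(NC2CC2)=Nc2ccc(F)cc21` has a core that differs from that of compound 1 in more than one place, and that difference is not broken down here. In this assay compound 2 also stops at the limit of > 300 uM. Compound 4 `O=S1(=O)NC(NC2CC2)=Nc2ccc(Br)cc21` differs from compound 2 by bromo in place of fluoro on an aromatic carbon, the same change as from compound 1 to compound 3. Compound 4 is expected to give about 60 uM in this assay, estimated between 15 uM and 300 uM. This estimate means an expected step of an at least 5.0-fold lower number from compound 2 to compound 4 (0.69 log units; beyond the scatter). The expectation for compound 4 rests on the measured step of an at least 9.6-fold lower number from compound 1 to compound 3 (0.98 log units; beyond the scatter).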

Compound 4, concentration for half-maximal effect: 89.4 uM
Compound 4: the middle estimate sits 1.5-fold (0.17 log units) below what was measured; the measured number falls inside the stated range.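

On the core of compound 2, bromo in place of fluoro again lowers the number in this assay, giving an at least 3.3-fold lower number from compound 2 to compound 4 (0.52 log units; beyond the scatter). The change therefore points the same way in both pairs, but whether it is equally large on each core stays unsettled: the same change on two cores in this assay, an at least 9.6-fold lower number (0.98 log units; beyond the scatter) from compound 1 to compound 3 and an at least 3.3-fold lower number (0.52 log units; beyond the scatter) from compound 2 to compound 4; the limit leaves it open whether they differ These two pairs show neither the true size of either step nor that the change would carry over to any further core, and the size stays uncertain for this reason: the limit of > 300 uM in this assay, at which 2 of the 4 values shown sit.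

The compounds shown leave open how chloro or a methoxy group on that same aromatic carbon would compare with bromo. They also leave open whether the change holds on a core carrying a longer chain on its amine nitrogen.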